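The compounds below may be only part of what the source reports. "The series", "measured", "known", "first", "only" and "open" are said of these compounds alone.

In a functional assay on the whole organism (strain albino) for inhibition, with Rattus norvegicus as the target, read by paw edema, with stated times of 1 h and 3 h, at a dose of 20 mmol/kg by the intraperitoneal route (on this read-out higher numbers stand for a stronger effect at the one dose given and lower numbers for a weaker effect), compound 3 `COc1ccc(/C=N/C2=C(C#N)C3C(N4CCCC4)CCCCN3C(=O)N2c2ccccc2)cc1` gives 75.3%. Among the three compounds measured, compound 3 stands second highest: compound 2 `CCOC(=O)C(=O)NC1=C(C#N)C2C(N3CCCC3)CCCCN2C(=O)N1c1ccccc1` gives 91.5%, and compound 1 `N#CC1=C(NCC(=O)N2CCCC2)N(c2ccccc2)C(=O)N2CCCCC(N3CCCC3)C12` gives 56%. The step of a number 16.2 percentage points lower from compound 2 to compound 3 (beyond the scatter) is modest, as is a number 19.3 percentage points higher from compound 1 to compound 3 (beyond the scatter), while a number 35.5 percentage points higher from compound 1 to compound 2 (beyond the scatter) is large. All three compounds share a core and differ only in the group on the double-bonded ring carbon.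

Compound 4 `N#CC1=C(/N=C/Nc2ccccc2)N(c2ccccc2)C(=O)N2CCCCC(N3CCCC3)C12` keeps that core and differs from compound 3 in one place: anilino in place of 4-methoxyphenyl on a carbon with a double bond to nitrogen. The two steps that bear on this position, a number 19.3 percentage points higher from compound 1 to compound 3 (beyond the scatter) and a number 16.2 percentage points lower from compound 2 to compound 3 (beyond the scatter), each replaced the whole group on the double-bonded ring carbon and gave modest shifts in opposite directions; the present change is smaller, an exchange of one aromatic substituent for another on a carbon with a double bond to nitrogen, the rest of the group staying as it is. For the measured compounds named here, no measured pair isolates such an exchange. A step of no more than modest size in either direction is therefore expected, most likely one within the scatter, giving a number 5.3 percentage points lower from compound 3 to compound 4 (within the scatter). Compound 4 is accordingly estimated at 70%, with a range from 50% to 88%.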

Compound 4, a percentage reported as inhibition, in the whole organism at one dose (the size of the read-out at that dose, not a potency): 79.3%
Estimate against measurement, compound 4: 9.3 percentage points below; measured number inside the range.
By their numbers in this assay, from the lowest: compound 1; then compounds 3 and 4 (each within the scatter of the next); then compound 2.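

In this assay, anilino in place of 4-methoxyphenyl on a carbon with a double bond to nitrogen gives a number 4 percentage points higher from compound 3 to compound 4 (within the scatter), so an exchange within the group, in which a hydrogen-bond acceptor leaves and a hydrogen-bond donor enters while an aromatic ring of carbon only stays, does not move the read-out beyond the scatter. Compound 4 stands apart from the other two as compound 3 does, with a number 12.2 percentage points lower from compound 2 to compound 4 (beyond the scatter) and a number 23.3 percentage points higher from compound 1 to compound 4 (beyond the scatter), so among the compounds shown, the shifts beyond the scatter come only with replacing the whole group on the double-bonded ring carbon, not with this exchange. Nothing measured here says why the read-out holds through this change.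

The compounds shown leave open whether a non-aromatic amine such as morpholin-4-yl, or a longer alkyl chain, in place of anilino on a carbon with a double bond to nitrogen would also stay within the scatter of compound 3. Going by these compounds, the nitrile, the phenyl and the pyrrolidin-1-yl group are the same throughout, so what a carboxylic acid or a piperidin-1-yl group in one of those places would do also remains open.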